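A few compounds are considered here, and "the series" means these few. Any claim that something is new, unique, unknown or untested is made for them only; others in the source may bear on it.

Measured so far in a functional assay on L1210 cells (Mus musculus) for antiproliferative activity, with a stated time of 48 h; on this read-out lower numbers stand for stronger inhibition and higher numbers for weaker inhibition:
compound 1 `COc1cccc(/C=C/C(=O)c2ccc(N)cc2)c1OC` gives 13000 nM
compound 2 `COc1ccc(/C=C/C(=O)c2ccc(N)cc2)c(OC)c1` gives 34000 nM

Compound 2 holds the higher of these two numbers, and the gap down to compound 1 lies beyond the scatter. Compound 2 is therefore the weaker inhibitor of the pair.

The next compound is compound 3 `COc1ccc(/C=C/C(=O)c2ccc(N)cc2)c(OC)c1OC`. It differs from compound 2 by methoxy in place of hydrogen on an aromatic carbon, ortho to two methoxy groups and meta to a large group (methoxy in place of hydrogen on an aromatic carbon). Among the measured compounds shown here, no step between measured compounds exists yet, so the effect of this change in this assay has not been observed directly.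

Compound 3 retains every methoxy group found in compound 1 and in compound 2. Its number is therefore expected to fall near the measured pair, leaning toward compound 1 at 13000 nM as the lower number. A modest move toward stronger inhibition is expected, with the estimated step being a 2.3-fold lower number from compound 2 to compound 3 (0.36 log units; beyond the scatter) for this change. The estimate for compound 3 is 15000 nM, with an expected range from 5000 nM to 45000 nM in this read-out.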

Compound 3, half-maximal inhibitory concentration: 25000 nM
Compound 3: middle estimate off by 1.7-fold (0.22 log units), on the low side; measured number inside the range.
By their numbers in this assay, from the lowest: compounds 1, 3 and 2 (each within the scatter of the next, the first and the last beyond it).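

In this assay, among the compounds shown here, methoxy in place of hydrogen on the aromatic carbon ortho to two methoxy groups and meta to a large group gives a 1.4-fold lower number from compound 2 to compound 3 (0.13 log units; within the scatter) and thus provides the first direct reading of this change at this position, with no effect that can be told from the scatter. The other methoxy addition leading to the same compound gives a 1.9-fold higher number from compound 1 to compound 3 (0.28 log units; within the scatter) and is also within the scatter, so neither step separates the added methoxy from repeat variation in this read-out. No measurement at hand bears on the reason for this result.

The compounds shown leave open whether another group on the same aromatic carbon, such as hydroxyl, a chlorine atom or a dimethylamino group, would produce a step beyond the scatter. They also leave open whether replacing the amino group of the shared core with an acetamide would change the response to methoxy at this position, since every compound here carries that amino group unchanged.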